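Moving the indole attachment point on a cytotoxicity read-out

The compounds below may be only part of what the source reports. "The series", "measured", "known", "first", "only" and "open" are said of these compounds alone.

Compound 1 `FC(F)(F)Oc1ccc(Nc2cc(-c3cccc4[nH]ccc34)ncn2)cc1` is one of three compounds examined in an ADME assay on BaF3 cells (Mus musculus) for cytotoxicity; on this read-out lower numbers stand for an effect already at smaller amounts and higher numbers for an effect only at larger amounts of compound. In this assay compound 1 gives 3790 nM. Of the two compounds with a number, this is the higher one, but its nearest neighbour, compound 2 `NC(=O)Cn1ncc2c(Nc3ccc(OC(F)(F)F)cc3)ncnc21`, sits very close: in this assay compound 2 gives 3300 nM, a gap that lies within the usual scatter, so no order between the two can be drawn from it. For compound 3 `Fc1ccc(Nc2cc(-c3ccncc3)ncn2)cc1` a limit is reported rather than a number: in this assay compound 3 gives > 10000 nM, which is a limit of the assay. The numbers on hand thus include (the limit of > 10000 nM in this assay, at which 1 of the 3 values shown sits).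

Compound 4 `FC(F)(F)Oc1ccc(Nc2cc(-c3ccc4[nH]ccc4c3)ncn2)cc1` differs from compound 1 only in 1H-indol-5-yl in place of 1H-indol-4-yl on an aromatic carbon; the two compounds have the same atoms, joined differently. Within the data shown here, no measured pair among the three compounds traces a change of this kind, so the size of the step cannot be read from a precedent. The half-maximal effective concentration of compound 4 is therefore expected to fall close to that of compound 1, with the step from one to the other expected to stay within the scatter in either direction. Compound 4 is expected to give about 4000 nM in this assay, between 1500 nM and 12000 nM. The step this estimate implies, a 1.1-fold higher number from compound 1 to compound 4 (0.02 log units; within the scatter), is expected to be none beyond the scatter.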

Compound 4, half-maximal effective concentration: > 10000 nM
Compound 4: no number, only a limit; the forecaster's own chance of this, stated with the estimate: 30%; at least 2.5-fold (0.39 log units) between middle value and limit.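

In this assay, the exchange on this aromatic carbon is not silent: moving the attachment point of the indole alone gives an at least 2.6-fold higher number from compound 1 to compound 4 (0.42 log units; beyond the scatter), even though the group that leaves and the group that enters have the same counts of heavy atoms, rings and hydrogen-bond donors. Among these compounds, the earlier compounds offered no pair differing in one place, so this is the first sign that, at this position on the shared core, the read-out responds to how the indole is attached and not only to the atoms it brings. The value of compound 4 is a limit and not a number, so the step has a lower bound but no upper one: the limit of > 10000 nM in this assay, at which 2 of the 4 values shown sit.

As far as these compounds go, how far compound 4 truly lies from compound 1 stays unknown, and a single pair cannot tell whether the same exchange would have a comparable effect on a different core. Also open, from the compounds shown here alone, is what a 1H-indol-6-yl group or a plain phenyl group would give on this same aromatic carbon, and whether either would fall nearer to compound 1 or to compound 4.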